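Replacing Phenyl with a Hydroxypiperidinylmethyl Group: Expected Cytotoxicity

The source may report more compounds than this note shows. Statements on the series, on what has been measured and on what is new or still open speak of the compounds shown alone.

Measured compounds:
- compound 1, `CN(C)c1ccc(-c2cn(-c3ccnc4cc(Cl)ccc34)nn2)cc1`: in an ADME assay on HepG2 cells (Homo sapiens) for cytotoxicity, read by MTT assay, with a stated time of 24 h (on this read-out lower numbers stand for higher toxicity in this test and higher numbers for lower toxicity in this test), compound 1 gives only a limit, > 2860000 nM.
- compound 2, `Clc1ccc2c(-n3cc(-c4ccccc4)nn3)ccnc2c1`: in this assay compound 2 gives 574000 nM.

Among the compounds with values here, compound 2 holds the only actual number in this assay; the value for compound 1 is a limit of the assay, not a number. Within the data shown here, the one measured step, an at least 4.9-fold lower number from compound 1 to compound 2 (0.69 log units; beyond the scatter), shows that removing the dimethylamino group moved the result from the limit of > 2860000 nM in this assay, at which 1 of the 2 values shown sits, down to a measured number.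

Compound 3, `OC1CCN(Cc2cn(-c3ccnc4cc(Cl)ccc34)nn2)CC1`, changes a different part of the shared core. Compared with compound 2 the difference is (4-hydroxypiperidin-1-yl)methyl in place of phenyl on an aromatic carbon. Among the measured compounds shown here, no measured step touches this position or this kind of group, so the step from compound 1 to compound 2 gives only a sense of how far a single change can move the number here, not its direction.

With that in mind, compound 3 is expected to sit at 1400000 nM, between 350000 nM and 3000000 nM, which would mean an estimated step of a 2.4-fold higher number from compound 2 to compound 3 (0.39 log units; beyond the scatter); the number may well come back as a limit.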

Compound 3, half-maximal cytotoxic concentration: 930000 nM
Beside the measured number, compound 3's estimate is 1.5-fold (0.18 log units) above it; low and high end bracket the measured number.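

Within the data shown here, this is the first measured look at the aromatic carbon of the five-membered aromatic ring with 3 nitrogen that carries phenyl in compound 2. In this assay, placing (4-hydroxypiperidin-1-yl)methyl there in place of phenyl gives a 1.6-fold higher number from compound 2 to compound 3 (0.21 log units; within the scatter), so an exchange of a six-membered aromatic ring of carbon only for a non-aromatic ring with 1 hetero atom, bringing 1 hydrogen-bond donor and 2 hydrogen-bond acceptors, leaves the two compounds indistinguishable in this test. Only compound 1 remains a limit of the assay rather than a number: the limit of > 2860000 nM in this assay, at which 1 of the 3 values shown sits.

A single exchange cannot show whether other groups at this position would behave the same way, such as a simple primary amine, a carboxylic acid or a longer chain in place of the methyl link. The compounds shown also do not separate the hydroxy group from the piperidine ring that carries it, and a plain piperidin-1-ylmethyl group would be the direct comparison.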